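A few compounds are considered here, and "the series" means these few. Any claim that something is new, unique, unknown or untested is made for them only; others in the source may bear on it.

Compound 2 `O=C(CCCCCCc1ccccc1)c1ncc(C(=O)C(F)(F)F)o1` is the stronger of the two measured inhibitors: in an assay (Rattus norvegicus) for inhibition of Fatty-acid amide hydrolase 1 (Homo sapiens) (a lower number here means a stronger inhibitor, a higher number a weaker inhibitor), compound 2 gives 4 nM, the lowest of the two numbers, while compound 1 `COc1ccccc1-c1cnc(C(=O)CCCCCCc2ccccc2)o1` gives 400 nM. Among the measured compounds shown here, the single measured step, a 100-fold lower number from compound 1 to compound 2 (2.00 log units; beyond the scatter), exchanges the 2-methoxyphenyl group on the shared core for the (trifluoromethyl)carbonyl group. Compound 3 `O=C(CCCCCCc1ccccc1)c1ncc(Cl)o1` alters that same place once more: chloro in place of (trifluoromethyl)carbonyl on an aromatic carbon, on an aromatic carbon of the five-membered aromatic ring with one nitrogen and one oxygen, next to the ring oxygen. The step from compound 1 to compound 2 shows that the group at this carbon can move this assay a great deal, and the (trifluoromethyl)carbonyl group is the one that gave the low number. Giving it up for chloro is therefore expected to raise the number markedly, a 75-fold higher number from compound 2 to compound 3 (1.88 log units; beyond the scatter), although no measured pair shows a chloro there. Compound 3 is estimated at 300 nM, with a range from 50 nM to 2000 nM.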

Compound 3, inhibition constant: 5 nM
For compound 3 the middle estimate is 60-fold (1.78 log units) above the measured one, and the stated range ends above it.
By their numbers in this assay, from the lowest: compounds 2 and 3 (each within the scatter of the next); then compound 1.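

With a 1.3-fold higher number from compound 2 to compound 3 (0.10 log units; within the scatter) in this assay, chloro cannot be told apart from (trifluoromethyl)carbonyl at this aromatic carbon, so the low number does not depend on the double bond or the hydrogen-bond acceptor of the (trifluoromethyl)carbonyl group. The large step seen earlier is also not tied to that one group, since an 80-fold lower number from compound 1 to compound 3 (1.90 log units; beyond the scatter) shows chloro in place of 2-methoxyphenyl giving a step of similar size, which leaves compound 1 as the one that stands apart among the three. No measurement at hand accounts for this match between two such different groups.

The compounds shown leave open whether a bromo group, a nitrile, an amine or a carboxylic acid at this carbon would keep the low number. They also leave open whether a plain phenyl group there would give a number like that of compound 1, which would separate the part played by the phenyl ring from that of its methoxy group.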